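This account rests on a few compounds, and the source may have more. Where it says the series, first, only, none or still open, it means among the compounds named here.

- Compound 1 `Cc1c2c(n3c1CCCN(C(=O)CN)[C@@H](C)[C@H](C)Nc1cc-3ccc1C(N)=O)CC(C)(C)CC2=O`: 481 nM
- Compound 2 `Cc1c2c(n3c1CCN(C(=O)CN)C[C@@H](C)[C@H](C)Nc1cc-3ccc1C(N)=O)CC(C)(C)CC2=O`: 378 nM
- Compound 3 `COCCC(=O)N1CCCc2c(C)c3c(n2-c2ccc(C(N)=O)c(c2)N[C@@H](C)[C@@H]1C)CC(C)(C)CC3=O`: 80 nM

All three compounds were tested in a functional assay on U-87MG ATCC cells (Homo sapiens) for antiproliferative activity; on this read-out lower numbers stand for stronger inhibition and higher numbers for weaker inhibition. The values of compound 1 and compound 2 lie within the usual scatter of each other, so these two cannot be ranked, while compound 3 gives a clearly lower number than either.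

Compound 4 `Cc1c2c(n3c1CCN(C(=O)[C@@H](N)C(C)C)C[C@@H](C)[C@H](C)Nc1cc-3ccc1C(N)=O)CC(C)(C)CC2=O` differs from compound 2 by a single change: isopropyl in place of hydrogen on a saturated chain carbon bound to an amine nitrogen and a carbonyl carbon. In words, this is isopropyl in place of hydrogen on a saturated chain carbon bound to an amine nitrogen and a carbonyl carbon.

Among the measured compounds shown here, only one measured step bears on this side chain: a 6.0-fold lower number from compound 1 to compound 3 (0.78 log units; beyond the scatter). It shows that a change there can move the number beyond the scatter, though modestly. However, that step removes the amino group, which compound 4 keeps. For the measured compounds named here, no measured step adds a group while the amino group stays, so the guidance is weak, and no shift beyond the scatter is expected in this assay. The expected step is a 1.3-fold lower number from compound 2 to compound 4 (0.10 log units; within the scatter). Compound 4 is estimated at 300 nM, with an expected range from 100 nM to 800 nM.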

Compound 4, half-maximal inhibitory concentration: 48 nM
Beside the measured number, compound 4's estimate is 6.3-fold (0.80 log units) above it; the measured number lies below the stated range.
By their numbers in this assay, from the lowest: compounds 4 and 3 (each within the scatter of the next); then compounds 2 and 1 (each within the scatter of the next).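

In this assay the addition of isopropyl on the saturated chain carbon bound to an amine nitrogen and a carbonyl carbon gives a 7.9-fold lower number from compound 2 to compound 4 (0.90 log units; beyond the scatter) and shows that this carbon responds to a new group while the amino group stays in place. The earlier step on this side chain, a 6.0-fold lower number from compound 1 to compound 3 (0.78 log units; beyond the scatter), removed the amino group, so it could not show that a clearly lower number is reachable with that group kept. Nothing measured here accounts for the size of the new step.

The compounds shown leave open whether a methyl or a phenyl group on the same carbon would move the number as far as isopropyl does. They also leave open whether isopropyl would have a similar effect on compound 1, whose core differs from that of compound 2.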